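A few compounds are considered here, and "the series" means these few. Any claim that something is new, unique, unknown or untested is made for them only; others in the source may bear on it.

In an ADME assay on SMMC-7721 cells (Homo sapiens) for cytotoxicity, read by MTT assay (on this read-out higher numbers stand for weaker inhibition and lower numbers for stronger inhibition), compound 1 (`Cc1cccc(O)c1C1=CC2=C(Cl)C(=O)[C@@](C)(O)C(=O)C2=CO1`) gives > 10000 nM, which is a limit of the assay and not a number. Compound 2 (`CCCCCC[C@H](C)/C=C(\C)C(=O)O[C@@]1(C)C(=O)C2=COC(c3c(C)cccc3O)=CC2=C(Cl)C1=O`) gives > 10000 nM, also only a limit, so it stands at the limit of > 10000 nM in this assay, at which 2 of the 2 values shown sit. Compound 3 (`CCCCCC[C@H](C)/C=C(\C)C(=O)O[C@@]1(C)C(=O)C2=COC(C3=C(C)CC(O)CC3=O)=CC2=C(Cl)C1=O`) carries 4-hydroxy-2-methyl-6-oxocyclohex-1-en-1-yl in place of 2-hydroxy-6-methylphenyl on a double-bonded ring carbon. For the measured compounds named here, no measured pair shows what this swap does, so no change beyond the usual scatter is expected in this assay. The expected move is small, a step that the limit leaves unreadable from compound 2 to compound 3. The estimate for compound 3 is 14000 nM, with an expected range of 5000 nM to 40000 nM.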

Compound 3, half-maximal inhibitory concentration: > 10000 nM
Compound 3 gave a limit, no number; the forecaster's own chance of this, stated with the estimate: 75%; the middle value does not contradict the limit.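

Compound 2 and compound 3 each give only a limit, not a number, so no step can be read between them. The compounds shown leave open whether swapping 2-hydroxy-6-methylphenyl for 4-hydroxy-2-methyl-6-oxocyclohex-1-en-1-yl changes inhibition at all.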